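The source may hold more compounds than are shown below. What is called first, only, known or untested is meant among the compounds shown, and "the series" means these compounds.

Measured so far in a functional assay on MDA-MB-453 cells (Homo sapiens) for cytotoxicity, read by MTT assay, with a stated time of 72 h (a higher number here means a weaker inhibitor, a lower number a stronger inhibitor), are three compounds:

- compound 1 `CC(C)(C)C1=CC(=O)C=C(NCCC(=O)O)C1=O` gives 94100 nM
- compound 2 `CC(C)(C)C1=CC(=O)C=C(NCC(=O)O)C1=O` gives 171000 nM
- compound 3 `CC1=CCC[C@H]2[C@](C)(CC3=CC(=O)C(N4CCC[C@H]4C(=O)O)=CC3=O)[C@@H](C)CC[C@]12C` gives 60600 nM

On these numbers, compound 3 cannot be told apart from compound 1, and only against compound 2 does it show a lower number beyond the scatter. Compound 4 `CC1=CCC[C@H]2[C@](C)(CC3=CC(=O)C=CC3=O)[C@@H](C)CC[C@]12C` has not been measured. It differs from compound 3 by one change, hydrogen in place of 2-carboxypyrrolidin-1-yl on a double-bonded ring carbon and so loses the whole acid-bearing group.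

Among the compounds with values here, only one measured step exists to lean on. It is a 1.8-fold higher number from compound 1 to compound 2 (0.26 log units; within the scatter) and it merely alters the chain that holds the acid, with carboxy in place of carboxymethyl. It therefore bears only weakly on removing the entire group. All three measured compounds carry such a group, so the data do not show what happens without one. A step toward a lower number in this assay is still expected, probably somewhat beyond the scatter, though this is a judgement with wide margins. The expected change is a 4.0-fold lower number from compound 3 to compound 4 (0.61 log units; beyond the scatter) as an estimate. Compound 4 is expected at 15000 nM with an estimated range from 3000 nM to 50000 nM at this stage.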

Compound 4, half-maximal inhibitory concentration: 16700 nM
Compound 4: middle estimate off by 1.1-fold (0.05 log units), on the low side; the range from low to high includes it.
By their numbers in this assay, from the lowest: compound 4; then compounds 3, 1 and 2 (each within the scatter of the next, the first and the last beyond it).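

In this assay, replacing the 2-carboxypyrrolidin-1-yl group with hydrogen on the double-bonded ring carbon gives a 3.6-fold lower number from compound 3 to compound 4 (0.56 log units; beyond the scatter), a modest step but one beyond the usual scatter. Within the data shown here, every earlier compound carried a carboxylic acid on a nitrogen-linked group, so this pair is the first to show this position with no such group, and it shows that the 2-carboxypyrrolidin-1-yl group, with its 8 heavy atoms, is not required for activity in this assay on this core. No supporting measurement bears on what lies behind this step.

This single pair cannot separate the part played by the carboxylic acid from that of the five-membered ring, so a plain pyrrolidin-1-yl group or a methyl ester of the acid at the same carbon would be needed to tell them apart. Also open, as far as these compounds go, is whether hydrogen would give a step of similar size on the core of compound 1, and how a small group such as methyl or a simple amine would compare with hydrogen at this position.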